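From methylsulfanyl to propoxy: the step to compound 4

The source may report more compounds than this note shows. Statements on the series, on what has been measured and on what is new or still open speak of the compounds shown alone.

In a functional assay on A549 cells (Homo sapiens) for cytotoxicity (a lower number here means that less compound is needed, a higher number that more compound is needed for the effect), compound 3 (`COc1cc(/C=C/c2ccc(SC)cc2)cc(OC)c1OC`) gives 4.7 uM as the middle of three numbers. Compound 1 (`CCOc1ccc(/C=C/c2cc(OC)c(OC)c(OC)c2)cc1`) lies lower, with 1.7 uM as its value, and compound 2 (`COc1ccc(/C=C\c2cc(OC)c(OC(C)=O)c(OC)c2)cc1`) lies higher, with 21.5 uM as its value. Compound 4 (`CCCOc1ccc(/C=C/c2cc(OC)c(OC)c(OC)c2)cc1`) has not yet been measured. It carries propoxy in place of methylsulfanyl on an aromatic carbon. Among the compounds with values here, one measured step bears on this change: methylsulfanyl in place of ethoxy gave a 2.8-fold higher number from compound 1 to compound 3 (0.44 log units; beyond the scatter) as a modest move beyond the scatter. Within the data shown here, compound 4 partly reverses that exchange, with propoxy standing where compound 1 has ethoxy, although no measured step compares propoxy with ethoxy. A modest step of about that size toward a lower number in this assay is therefore expected. The estimate means a 2.1-fold lower number from compound 3 to compound 4 (0.33 log units; beyond the scatter) as the expected step. For compound 4 the expected value is 2.2 uM (estimated range 0.8 uM to 6 uM).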

Compound 4, concentration for half-maximal effect: 9.2 uM
For compound 4 the middle estimate is 4.2-fold (0.62 log units) below the measured one; measured number outside the range, above it.
By their numbers in this assay, from the lowest: compound 1; then compounds 3 and 4 (each within the scatter of the next); then compound 2.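

Within the data shown here, the new compound shows that this position responds to the length of the alkoxy chain, which the earlier compounds could not show. In this assay, adding one methyl to the ethoxy chain gave a 5.4-fold higher number from compound 1 to compound 4 (0.73 log units; beyond the scatter), so propoxy does not stand in for ethoxy here. Propoxy and methylsulfanyl, by contrast, cannot be told apart, with a 2.0-fold higher number from compound 3 to compound 4 (0.29 log units; within the scatter), and the earlier exchange of ethoxy for methylsulfanyl therefore says little about propoxy. Nothing available explains why the extra methyl matters at this position. On these data alone, it remains open whether a longer chain such as butoxy would continue the trend seen from ethoxy to propoxy, and how an amine on this aromatic carbon would compare with these groups.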